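Aryl-piperidinyl pyridine esters: aorta relaxation series, working notes

The compounds below may be only part of what the source reports. "The series", "measured", "known", "first", "only" and "open" are said of these compounds alone.

Measured compounds and their readings:
compound 1 `CCOC(=O)c1c(-c2ccc(F)cc2)cc(-c2ccccc2)nc1N1CCCCC1`, 346000 nM
compound 2 `CCOC(=O)c1c(-c2ccc(C)cc2)cc(-c2ccccc2)nc1N1CCN(c2nc(-c3ccccc3)cc(-c3ccc(C)cc3)c2C(=O)OCC)CC1`, 229000 nM
compound 3 `CCOC(=O)c1c(-c2ccc(F)cc2)cc(-c2ccccc2)nc1Nc1ccccc1`, 367000 nM

All three were run in a functional assay on thoracic aorta (strain Wistar) with Aorta (Rattus norvegicus) as the target, with a stated time of 2 h; a higher number here means a weaker inhibitor, a lower number a stronger inhibitor. Compound 1 stands second highest of the three numbers; its nearest neighbour is compound 3, and the step of a 1.1-fold higher number from compound 1 to compound 3 (0.03 log units; within the scatter) lies within the scatter. Within the data shown here, compound 2, the dimeric ester built on a piperazine linker, gives the lowest of the three numbers, but no single-point step connects it to compound 1, and the gap between the two values is itself within the scatter. In short, the three measured compounds are indistinguishable on this read-out.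

Compound 4 `CCOC(=O)c1c(-c2ccc(F)cc2)cc(-c2ccccc2)nc1Nc1ccc(Cl)cc1` is the next point. Relative to compound 1 the change is (4-chlorophenyl)amino in place of piperidin-1-yl on an aromatic carbon. Among the measured compounds shown here, the one measured step that bears on it is the exchange of piperidin-1-yl for anilino, from compound 1 to compound 3, which produced no shift beyond the scatter. For the measured compounds named here, compound 4 carries the same type of exchange with a chlorine added on the entering aromatic ring; nothing among the measured compounds reports what that chlorine does. The expectation is therefore a step of about a 1.0-fold higher number from compound 1 to compound 4 (0.00 log units; within the scatter), in no particular direction, within the scatter.

For compound 4 the estimated value in this assay is 350000 nM, with a range from 150000 nM to 800000 nM.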

Compound 4, half-maximal inhibitory concentration: 715000 nM
For compound 4 the middle estimate is 2.0-fold (0.31 log units) below the measured one; the measured number falls inside the stated range.
By their numbers in this assay, from the lowest: compounds 2, 1, 3 and 4 (each within the scatter of the next, the first and the last beyond it).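

In this assay, among these compounds, the exchange at this position, next to the ring nitrogen and ortho to the ethoxycarbonyl group, now gives a first step beyond the scatter: a 2.1-fold higher number from compound 1 to compound 4 (0.32 log units; beyond the scatter), a modest one, whereas the unsubstituted anilino exchange gave a 1.1-fold higher number from compound 1 to compound 3 (0.03 log units; within the scatter). The chlorine alone does not separate from the scatter, with chloro in place of hydrogen giving a 1.9-fold higher number from compound 3 to compound 4 (0.29 log units; within the scatter), so only the full exchange of piperidin-1-yl for (4-chlorophenyl)amino can be read as a change in this series, and the share of the chlorine in it stays unresolved. Nothing available explains this step.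

The compounds shown leave open whether a methoxy group or a nitrile in place of the chlorine would move the number in the same direction, or whether this is particular to chloro. They also leave open what a morpholin-4-yl group or a simple amino group would do at this position, and whether any replacement here can bring the number below that of compound 1 by more than the scatter.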